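Swapping 4-fluorophenyl for 3-nitrophenyl

The source may report more compounds than this note shows. Statements on the series, on what has been measured and on what is new or still open speak of the compounds shown alone.

Within the data shown here, in a functional assay on PC-3 cells (Homo sapiens) for inhibition, read by sulforhodamine B assay, with a stated time of 48 h, tested at 50 uM (a higher number here means more inhibition of growth at the concentration tested, a lower number less inhibition of growth), compound 3 `COc1cc2c(cc1CC=C(C)C)C(=O)C[C@@H](c1ccc(Oc3ccc(F)cc3)cc1)O2` gives 19%, the lowest of the three numbers so far, while compound 1 `CCCOc1ccc([C@@H]2CC(=O)c3cc(CC=C(C)C)c(OC)cc3O2)cc1` gives 54% and compound 2 `COc1ccc([C@@H]2CC(=O)c3cc(CC=C(C)C)c(OC)cc3O2)cc1` gives 58%. Compound 4 `COc1cc2c(cc1CC=C(C)C)C(=O)C[C@@H](c1ccc(Oc3cccc([N+](=O)[O-])c3)cc1)O2` keeps the shared core and carries 3-nitrophenyl in place of 4-fluorophenyl on an oxygen on an aromatic ring. Two large steps bear on this change: a number 35 percentage points lower from compound 1 to compound 3 (beyond the scatter) and a number 39 percentage points lower from compound 2 to compound 3 (beyond the scatter), both installing 4-fluorophenyl on that oxygen. The step of a number 4 percentage points higher from compound 1 to compound 2 (within the scatter) changes only the chain there. Among the measured compounds shown here, no measured step compares two aromatic groups on that oxygen, and compound 4 keeps a six-membered aromatic ring of carbon only there. The expected change is therefore small, with an estimated a number 5 percentage points higher from compound 3 to compound 4 (within the scatter). Compound 4 is expected to give 24%, within an estimated range of 7% to 45%.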

Compound 4, percent growth inhibition at one concentration: 21%
Beside the measured number, compound 4's estimate is 3 percentage points above it; the measured number falls inside the stated range.
By their numbers in this assay, from the lowest: compounds 3 and 4 (each within the scatter of the next); then compounds 1 and 2 (each within the scatter of the next).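

In this assay two aromatic groups on this oxygen can now be compared, and 3-nitrophenyl in place of 4-fluorophenyl leaves them inseparable (a number 2 percentage points higher from compound 3 to compound 4 (within the scatter)). Compound 4 also stays well under both chain compounds (a number 37 percentage points lower from compound 2 to compound 4 (beyond the scatter); a number 33 percentage points lower from compound 1 to compound 4 (beyond the scatter)), so the drop seen with compound 3 is not specific to 4-fluorophenyl but appears with both aromatic groups shown. Nothing measured here explains this drop.

Still open, as far as these compounds go, is whether an unsubstituted phenyl, a benzyl group or a saturated cyclohexyl ring on this oxygen would sit with the chain compounds or with the aromatic ones.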